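A few compounds are considered here, and "the series" means these few. Any claim that something is new, unique, unknown or untested is made for them only; others in the source may bear on it.

Measured so far:
- compound 1 `Cc1nc2c(cnn2-c2ccccc2)c(=O)n1C1CCCCCC1`: 760 nM
- compound 2 `Cc1nc2c(cnn2CC2CCCCC2)c(=O)n1-c1ccc(Cl)cc1`: > 100000 nM

In an in vitro functional assay on cells for antagonist activity at metabotropic glutamate receptor 1 (Homo sapiens), read by FLIPR and calcium flux (on this read-out lower numbers stand for stronger inhibition and higher numbers for weaker inhibition), compound 1 gives 760 nM. For compound 2 the read-out in this assay is a limit of the assay and not a number: > 100000 nM. Among the measured compounds shown here, the two measurements thus rest on one number and on (the limit of > 100000 nM in this assay, at which 1 of the 2 values shown sits), so compound 2 stands at the weak end of what this assay can report, with no numerical step between the two measured compounds to compare against.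

Compound 3 `Cc1ccccc1-n1ncc2c(=O)n(-c3ccc(Cl)cc3)c(C)nc21` differs from compound 2 by 2-methylphenyl in place of cyclohexylmethyl on an aromatic nitrogen. For the measured compounds named here, the one measured compound that carries an aromatic ring on an aromatic nitrogen of that five-membered ring, compound 1, sits at the stronger end of the two values in this assay, which is the only pointer available; compound 1 also differs from compound 3 elsewhere, so the pointer is weak.

The step from compound 2 to compound 3 is therefore expected to run toward stronger inhibition and beyond the scatter, estimated as an at least 12-fold lower number from compound 2 to compound 3 (1.09 log units; beyond the scatter). Compound 3 is estimated at 8000 nM, with a range from 800 nM to 100000 nM, and a fair chance remains that this assay again reports only a limit.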

Compound 3, half-maximal inhibitory concentration: 350 nM
Compound 3: middle estimate off by 23-fold (1.36 log units), on the high side; measured number outside the range, below it.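

In this assay, among the compounds shown here, replacing cyclohexylmethyl with 2-methylphenyl on an aromatic nitrogen gives an at least 280-fold lower number from compound 2 to compound 3 (2.45 log units; beyond the scatter), the first readable evidence that inhibition depends strongly on the group at this position. The two groups have the same count of heavy atoms, all of them carbon, and each has one six-membered ring and no hydrogen-bond donors or acceptors, so these counts do not separate them; the printed difference is an aromatic ring in place of a non-aromatic one, and this single pair cannot show that this difference alone accounts for the step. From the compounds shown here alone, the value for compound 2 is a limit of the assay and not a number, so the true size of the step remains unknown: the limit of > 100000 nM in this assay, at which 1 of the 3 values shown sits.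

For the compounds shown here, compound 1 differs from compound 3 in more than one place, so no step between them can be read, and the part played by the methyl of 2-methylphenyl remains unresolved. Also open, going by these compounds, is how this position would respond to an aromatic ring carrying an amine or a carboxylic acid, or to a longer chain.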